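The compounds below may be only part of what the source reports. "The series", "measured", "known", "first", "only" and "open" are said of these compounds alone.

In a functional assay on SH-SY5Y cells (Homo sapiens) for cytotoxicity, read by MTT assay, with stated times of 8 h, 30 min and 12 h, tested at 0.5 uM (a lower number here means a weaker effect, a higher number a stronger effect of the compound at the concentration tested), compound 1 `N=C(NCc1ccc(O)cc1)[C@@H]1CCC(=O)N1Cc1ccccc1` gives 35.4%, compound 2 `COc1ccc(CNC(=N)[C@@H]2CCC(=O)N2Cc2ccccc2)cc1` gives 23.6% and compound 3 `N=C(NCc1ccc(O)cc1)[C@@H]1CCC(=O)N1Cc1ccc([N+](=O)[O-])cc1` gives 31.3%. Compound 2 has the lowest of the three numbers, though compound 3 sits within the scatter of it and only compound 1 lies beyond it, the step of a number 11.8 percentage points lower from compound 1 to compound 2 (beyond the scatter) being a modest one. Compound 4 `COc1ccc(CNC(=N)[C@@H]2CCC(=O)N2Cc2ccc(F)cc2)cc1` differs from compound 2 as follows: fluoro in place of hydrogen on an aromatic carbon. Within the data shown here, the single measured step on that same ring, a number 4.1 percentage points lower from compound 1 to compound 3 (within the scatter), stayed within the scatter, and nothing measured speaks for a larger effect of one substituent there. Compound 4 is therefore expected to change little, with the step of a number 0.4 percentage points higher from compound 2 to compound 4 (within the scatter) staying within the scatter. The value of compound 4 in this assay is estimated at 24%, between 13% and 35%.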

Compound 4, a percentage reported as activity, at one concentration (the size of the read-out at that concentration, not a potency): 36.7%
Beside the measured number, compound 4's estimate is 12.7 percentage points below it; the measured number lies above the stated range.
By their numbers in this assay, from the lowest: compounds 2, 3, 1 and 4 (each within the scatter of the next, the first and the last beyond it).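

In this assay, this assay, the step of a number 13.1 percentage points higher from compound 2 to compound 4 (beyond the scatter) shows that fluoro on this aromatic carbon, para to a large group, can move the number beyond the scatter. The earlier nitro step on the same ring, a number 4.1 percentage points lower from compound 1 to compound 3 (within the scatter), did not show this, so that ring can no longer be treated as silent, at least in compound 4. No measurement shown accounts for the rise. On these data alone, it remains open whether chloro or methyl on this carbon would give a similar step, and whether fluoro would do the same on compound 1.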